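This account rests on a few compounds, and the source may have more. Where it says the series, first, only, none or still open, it means among the compounds named here.

Measured compounds in a functional assay on SF-295 cells (Homo sapiens) for antiproliferative activity; a lower number here means a stronger inhibitor of growth, a higher number a weaker inhibitor of growth:

- compound 1 `Cc1ccnc2nc(-c3cccc(Cl)c3)cc(O)c12` gives 40.7 nM
- compound 3 `Cc1cc(C)c2c(O)cc(-c3cccc(Cl)c3)nc2n1` gives 47.9 nM
- compound 2 `Cc1cc(C)c2c(O)cc(-c3cccc4ccccc34)nc2n1` gives 589 nM

Compound 2 stands apart from the other two: the difference between its core and the core of compound 3 is not broken down here, and the values alone show compound 2 with the highest number of the three, beyond the scatter against both.

One change is seen twice in the set. From compound 3 to compound 1 it is hydrogen in place of methyl on an aromatic carbon, and in this assay it gave a 1.2-fold lower number from compound 3 to compound 1 (0.07 log units; within the scatter).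

Compound 4 `Cc1ccc2c(O)cc(-c3cccc4ccccc34)nc2n1` is the unmeasured partner of compound 2. The change is hydrogen in place of methyl on an aromatic carbon. The surroundings differ from the earlier case: there the place was next to the ring nitrogen and para to a fused ring, here it is ortho to a fused ring and opposite the ring nitrogen, so this is the same kind of change, not the same change.

Resting on the earlier step from compound 3 to compound 1 a 1.2-fold lower number from compound 3 to compound 1 (0.07 log units; within the scatter), the expected step from compound 2 to compound 4 in this assay is a 1.2-fold lower number from compound 2 to compound 4 (0.07 log units; within the scatter). Compound 4 is therefore estimated at 500 nM, with the expected range 200 nM to 1500 nM.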

Compound 4, concentration for 50% growth inhibition: 24 nM
For compound 4 the middle estimate is 21-fold (1.32 log units) above the measured one, and the stated range ends above it.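

In this assay, hydrogen in place of methyl on an aromatic carbon gave a 25-fold lower number from compound 2 to compound 4 (1.39 log units; beyond the scatter), and the size of this step did not carry over from the earlier case: the same change on two cores in this assay, a 1.2-fold lower number (0.07 log units; within the scatter) from compound 3 to compound 1 and a 25-fold lower number (1.39 log units; beyond the scatter) from compound 2 to compound 4, 21-fold (1.32 log units) apart, beyond the scatter of two such steps

In this series, then, a step read on one core is no guide to the size of the same kind of change on another, and this change cannot be carried across as a fixed increment. Two steps do not separate the influence of the methyl's place from that of the rest of the core, so they give no cause for the gap and no rule for a further core.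

Still open, going by these compounds, is how a longer chain, such as ethyl, or an amine or methoxy group at the place of the methyl in compound 2 would compare with methyl and hydrogen. Also open is whether the large step recurs on other cores that carry a methyl at this place, or remains confined to the pair shown here.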